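Swapping cyclopropyl for trifluoromethyl: an expected cytotoxicity

The source may report more compounds than this note shows. Statements on the series, on what has been measured and on what is new or still open speak of the compounds shown alone.

In an ADME assay on H1-HeLa cells (Homo sapiens) for cytotoxicity, read by MTT assay, with a stated time of 3 days (on this read-out higher numbers stand for lower toxicity in this test and lower numbers for higher toxicity in this test), compound 1 (`CNC(=O)c1cc(Oc2ccc3c(C)c(-c4noc(C(C)C)n4)sc3c2)ccn1`) gives 5500 nM and compound 2 (`CNC(=O)c1cc(Oc2ccc(-c3noc(C4CC4)n3)cc2)ccn1`) gives 32300 nM as the higher of the two numbers, a gap beyond the usual scatter. Compound 3 (`CNC(=O)c1cc(Oc2ccc(-c3noc(C(F)(F)F)n3)cc2)ccn1`) differs from compound 2 in one place, with trifluoromethyl in place of cyclopropyl on an aromatic carbon. Within the data shown here, no measured pair shows this swap, so the expectation rests on compound 2 at 32300 nM as the closest reference. In this assay the expected change is a 1.1-fold lower number from compound 2 to compound 3 (0.03 log units; within the scatter) and no shift in either direction beyond the scatter is expected. Compound 3 is estimated at 30000 nM with an expected range from 11000 nM to 80000 nM in this test.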

Compound 3, half-maximal cytotoxic concentration: 35000 nM
The estimate for compound 3 lay 1.2-fold (0.07 log units) below the measured number; the range from low to high includes it.
By their numbers in this assay, from the lowest: compound 1; then compounds 2 and 3 (each within the scatter of the next).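

In this assay, among these compounds, trifluoromethyl in place of cyclopropyl on this aromatic carbon gives a 1.1-fold higher number from compound 2 to compound 3 (0.03 log units; within the scatter) and so offers the first one-place comparison at this position. Here, losing the three-membered ring and gaining three fluorine atoms leaves the read-out within the scatter. No available evidence bears on this result.

From the compounds shown here alone, whether an amine or a longer chain on this carbon would also stay within the scatter remains open. So does whether this swap would behave the same way on the core of compound 1.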